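The source may report more compounds than this note shows. Statements on the series, on what has been measured and on what is new or still open speak of the compounds shown alone.

Measured in an ADME assay on MCF-10A cells (Homo sapiens) for cytotoxicity, read by MTT assay, with a stated time of 48 h; a lower number here means a stronger inhibitor, a higher number a weaker inhibitor:
- compound 1 `COc1cc(C#N)ccc1OCc1nnc(-c2ccc(Cl)cc2)o1`: 89500 nM
- compound 2 `N#Cc1ccc(OCc2nnc(-c3ccccc3)o2)cc1F`: > 100000 nM (a limit)
- compound 3 `COc1ccc(-c2nnc(COc3ccc(C#N)c(F)c3)o2)cc1`: > 100000 nM (a limit)

In this assay compound 3 stands at > 100000 nM, which is a limit and not a number. The set shows (the limit of > 100000 nM in this assay, at which 2 of the 3 values shown sit). Compound 4 `N#Cc1ccc(OCc2nnc(-c3ccc(F)cc3)o2)cc1F` carries fluoro in place of methoxy on an aromatic carbon, para to a large group: fluoro in place of methoxy on an aromatic carbon. Going by the values given here, the one measured step at this place is a step that the two limits leave unreadable from compound 2 to compound 3, so its size gives no guide. Among the compounds with values here, compound 1 gives the only true number, 89500 nM, but it differs from compound 3 in more than one place. The expected change, a number no higher from compound 3 to compound 4 (the limit leaves the size open), is none beyond the scatter, in neither direction. For compound 4 the estimate is 100000 nM, with an expected range of 50000 nM to 200000 nM.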

Compound 4, half-maximal inhibitory concentration: 84200 nM
The estimate for compound 4 lay 1.2-fold (0.07 log units) above the measured number; the measured number falls inside the stated range.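

At this position in this assay, compound 4 gives the first true number, 84200 nM, for a group on this aromatic carbon. The change from methoxy reads as an at least 1.1-fold lower number from compound 3 to compound 4 (0.07 log units; that floor lies within the scatter), and the change from hydrogen reads as an at least 1.1-fold lower number from compound 2 to compound 4 (0.07 log units; that floor lies within the scatter), so a real change is neither shown nor excluded. The two other compounds with this change of position remain limits and not numbers: the limit of > 100000 nM in this assay, at which 2 of the 4 values shown sit.

The compounds shown leave open how an amine or a carboxylic acid on this aromatic carbon would read in this assay.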